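Chloro for phenyl after two unreadable limits

The source may hold more compounds than are shown below. What is called first, only, known or untested is meant among the compounds shown, and "the series" means these compounds.

Compound 1 `CCOC(=O)c1c(-c2cccc(-c3ccccc3)c2)[nH]c2cc(OC)ccc2c1=O` and compound 2 `CCOC(=O)c1c(-c2cccc(-c3ccccc3)c2)[nH]c2cc(OC)c(Cl)cc2c1=O` differ by chloro in place of hydrogen on an aromatic carbon. In an ADME assay on HEK293 cells (Homo sapiens) for cytotoxicity, read by luminescence, with a stated time of 72 h (a lower number here means that less compound is needed, a higher number that more compound is needed for the effect), compound 1 gives only a limit, > 22000 nM. In this assay compound 2 also gives only a limit, > 22000 nM. The step that the two limits leave unreadable from compound 1 to compound 2 therefore cannot be read, both values resting on (the limit of > 22000 nM in this assay, at which 2 of the 2 values shown sit). Compound 3 `CCOC(=O)c1c(-c2cccc(Cl)c2)[nH]c2cc(OC)c(Cl)cc2c1=O` differs from compound 2 by chloro in place of phenyl on an aromatic carbon. Within the data shown here, no measured step bears on this change, so no direction beyond the scatter is expected. Compound 3 is expected to give 30000 nM, within 12000 nM to 100000 nM, most likely again as a limit. The expected step is a step that the limit leaves unreadable from compound 2 to compound 3.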

Compound 3, half-maximal effective concentration: > 22000 nM
Compound 3: a limit, no number (the forecaster's own chance of this, stated with the estimate: 75%); the middle value does not contradict the limit.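

Compound 3 gives > 22000 nM, again only a limit, so the step between compound 2 and compound 3 cannot be read. From the compounds shown here alone, what concentration of compounds 1, 2 or 3 would reach the half-maximal effect in this assay remains open.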